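The source may report more compounds than this note shows. Statements on the series, on what has been measured and on what is new or still open speak of the compounds shown alone.

Measured so far in a functional assay on MDA-MB-231 cells (Homo sapiens) for inhibition, read by MTT assay; on this read-out lower numbers stand for stronger inhibition of growth and higher numbers for weaker inhibition of growth:
- compound 1 `CC1=C(/C=C/C(C)=C/C=C/C(C)=C\C(=O)Nc2ccccc2)C(C)(C)CCC1n1ccnc1`: 1740 nM
- compound 2 `CC1=C(/C=C/C(C)=C/C=C/C(C)=C\C(=O)Nc2ccc(O)cc2)C(C)(C)CCC1n1ccnc1`: 13100 nM

Compound 2 holds the higher of the two numbers, so it is the weaker inhibitor of growth here. The gap between the two is a 7.5-fold higher number from compound 1 to compound 2 (0.88 log units; beyond the scatter), a modest step beyond the scatter, with hydroxy in place of hydrogen on an aromatic carbon.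

Next in the series is compound 3 `CC1=C(/C=C/C(C)=C/C=C/C(C)=C\C(=O)NCc2cccc(F)c2)C(C)(C)CCC1n1ccnc1`, with the change 3-fluorobenzyl in place of 4-hydroxyphenyl on an amide-type nitrogen. The hydroxy leaves with this change, and that is the only part of it the data touch. Compound 1, which also lacks the hydroxy, stands at 1740 nM, so a lower number than that of compound 2 is expected in this assay. Among the compounds with values here, no measured step covers the fluorine or a benzyl group on the amide nitrogen, so the expectation stays loose and a full return to the level of compound 1 is not assumed. The expected step is a 4.4-fold lower number from compound 2 to compound 3 (0.64 log units; beyond the scatter). For compound 3 the estimate is 3000 nM, with an expected range of 900 nM to 10000 nM.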

Compound 3, concentration for 50% growth inhibition: 1650 nM
Beside the measured number, compound 3's estimate is 1.8-fold (0.26 log units) above it; measured number inside the range.
By their numbers in this assay, from the lowest: compounds 3 and 1 (each within the scatter of the next); then compound 2.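

At this position, on an amide-type nitrogen, this assay shows that a second group can match the unsubstituted phenyl: the step of a 7.9-fold lower number from compound 2 to compound 3 (0.90 log units; beyond the scatter) is modest but beyond the scatter, and it brings the series back to the level of compound 1. The step of a 1.1-fold lower number from compound 1 to compound 3 (0.02 log units; within the scatter) lies within the scatter, so this read-out does not separate 3-fluorobenzyl from phenyl, and this position accepts both groups without a measurable difference in growth inhibition. Nothing at hand gives a reason for this result or for the weaker number of compound 2.

The change to 3-fluorobenzyl alters the aromatic group in more than one way, so the compounds shown cannot separate the contribution of the fluorine from that of the benzyl form. An unsubstituted benzyl group would address that split, while a 4-hydroxybenzyl group would test whether the hydroxy step seen on the phenyl group carries over to a benzyl group, and a primary amine or carboxylic acid on the ring remains an open question at this position.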